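The compounds below may be only part of what the source reports. "The series", "measured", "known", "first", "only" and "open" are said of these compounds alone.

Compound 1 `OCCCNCc1nc2c(OCC3CCCCC3)cccc2[nH]1` stands lowest of the three measured compounds in an assay on cells for inhibition of interleukin-5 receptor subunit alpha (Mus musculus), read by WST assay, with a stated time of 48 h, tested at 30 uM, in the presence of a further agent that is not named here (on this read-out lower numbers stand for less inhibition and higher numbers for more inhibition at the one concentration tested (going by the name of the read-out)), where compound 1 gives 52.7%. Its two neighbours carry other groups on the amine nitrogen: compound 2 `CCCC(CO)NCc1nc2c(OCC3CCCCC3)cccc2[nH]1` gives 73.3% in this assay, and compound 3 `OCC(NCc1nc2c(OCC3CCCCC3)cccc2[nH]1)c1ccccc1` gives 77.7%. Both steps away from compound 1 are of a similar kind: a number 20.6 percentage points higher from compound 1 to compound 2 (beyond the scatter) and a number 25 percentage points higher from compound 1 to compound 3 (beyond the scatter), while the phenyl-for-propyl exchange gives a number 4.4 percentage points higher from compound 2 to compound 3 (within the scatter), a difference that does not stand out from the scatter.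

The unmeasured compound 4 `COc1ccc(CNCc2nc3c(OCC4CCCCC4)cccc3[nH]2)cc1` differs from compound 1 in one place: 4-methoxyphenyl in place of 2-hydroxyethyl on a saturated chain carbon bound to an amine nitrogen. The step from compound 1 to compound 3 bears on this most closely, since it also brings an aromatic ring onto the chain carbon bound to the amine nitrogen, and it was modest and upward. Among the compounds with values here, no measured pair, however, shows what the loss of the hydroxyl group does, so that part of the change is unknown. Compound 4 is therefore expected to sit higher than compound 1 by a modest step, a number 12.3 percentage points higher from compound 1 to compound 4 (beyond the scatter), with wide uncertainty. Compound 4 is estimated at 65%, with a range from 45% to 85%.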

Compound 4, a percentage reported as inhibition, at one concentration (the size of the read-out at that concentration, not a potency): 43.3%
The estimate for compound 4 lay 21.7 percentage points above the measured number; the measured number lies below the stated range.
By their numbers in this assay, from the lowest: compounds 4 and 1 (each within the scatter of the next); then compounds 2 and 3 (each within the scatter of the next).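

In this assay, an aromatic ring on this chain carbon is not enough to lift the number: 4-methoxyphenyl in place of 2-hydroxyethyl gives a number 9.4 percentage points lower from compound 1 to compound 4 (within the scatter), so the 3-hydroxypropyl to 4-methoxybenzyl change leaves compound 4 level with compound 1. The contrast lies instead with the two groups on the amine nitrogen that bear a hydroxymethyl on the carbon bound to that nitrogen, with a number 34.4 percentage points lower from compound 3 to compound 4 (beyond the scatter) and a number 30 percentage points lower from compound 2 to compound 4 (beyond the scatter). Neither the aromatic ring alone nor the hydroxyl alone accounts for the higher numbers among these four compounds, since compound 4 has the ring without the hydroxyl and compound 1, which goes against any reading based on the hydroxyl alone, has the hydroxyl without the ring or the branch.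

Nothing available here gives a reason for these differences. Still open, on these data alone, is whether an amine or a carboxylic acid in place of the hydroxyl of 2-hydroxy-1-phenylethyl would keep the number of compound 3, and whether a longer chain in place of the propyl of compound 2 would change it.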